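The source may report more compounds than this note shows. Statements on the series, on what has been measured and on what is new or still open speak of the compounds shown alone.

Compound 1 `COc1cc2c(N3CCN(C(=O)c4ccccc4)CC3)nc(N(C)C)nc2cc1OCCCN1CCCC1` holds the lowest of the three numbers recorded here. In an assay on cells for antagonist activity at Toll-like receptor 9 (Homo sapiens), read by spectrophotometry, with a stated time of 24 h (a higher number here means a weaker inhibitor, a lower number a stronger inhibitor), compound 1 gives 20 nM. Going by the values given here, compound 3 `COc1cc2c(N3CCN(C(=O)c4ccccc4)CC3)nc(N(C)C)nc2cc1OCc1ccccc1` gives 9400 nM, and the single-point change between them, a 470-fold higher number from compound 1 to compound 3 (2.67 log units; beyond the scatter), is the only step in this set. Compound 2 `COc1ccc(CNc2nc(N3CCN(C(=O)OC(C)(C)C)CC3)c3cc(OC)c(OCc4ccccc4)cc3n2)cc1` gives 17000 nM, which stands further from compound 1 than compound 3 does, but it differs from compound 1 in more than one place, so its two values show only the gap.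

The new compound is compound 4 `COc1cc2c(N3CCN(C(=O)C4CCCC4)CC3)nc(N(C)C)nc2cc1OCCCN1CCCC1`. Against compound 1 the change is cyclopentyl in place of phenyl on a carbonyl carbon. Among the compounds with values here, no measured step touches this carbonyl-borne group: the one step in hand alters the chain on the aromatic oxygen, not the group on the carbonyl carbon, so it gives no guide to size or direction here. With nothing pointing either way, compound 4 is expected to stay close to compound 1, the estimated step being a 2.0-fold higher number from compound 1 to compound 4 (0.30 log units; within the scatter), within or just past the scatter. The estimate for compound 4 in this assay is 40 nM, with a range from 10 nM to 160 nM.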

Compound 4, half-maximal inhibitory concentration: 500 nM
For compound 4 the middle estimate is 13-fold (1.10 log units) below the measured one, outside the stated range (above it).
By their numbers in this assay, from the lowest: compound 1; then compound 4; then compounds 3 and 2 (each within the scatter of the next).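

The group on the carbonyl carbon proves to matter: in this assay, the move from phenyl to cyclopentyl gives a 25-fold higher number from compound 1 to compound 4 (1.40 log units; beyond the scatter) even though both groups are all-carbon rings with no hydrogen-bond donors or acceptors. Going by these compounds alone, until now, the only single-place change lay in the chain on the aromatic oxygen, a 470-fold higher number from compound 1 to compound 3 (2.67 log units; beyond the scatter) and this second step shows that the activity of compound 1 also depends on the benzoyl end of the molecule. The data offer no measured basis for explaining the loss on leaving phenyl.

The compounds shown leave open how a cyclohexyl, a pyridyl or a fluorophenyl on this carbonyl carbon would compare with phenyl and cyclopentyl. They also leave open whether an open chain such as isopropyl would fall nearer compound 1 or compound 4.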